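Trifluoromethyl to Dichloro on the Benzyl Ether

The source may report more compounds than this note shows. Statements on the series, on what has been measured and on what is new or still open speak of the compounds shown alone.

Compound 1 `Cc1ccc(NC(=S)NC(=O)c2ccc(OCc3cccc(C(F)(F)F)c3)cc2)cc1-c1nc2ccccc2[nH]1` and compound 2 `Cc1ccc(NC(=S)NC(=O)c2ccc(OCc3ccccc3Cl)cc2)cc1-c1nc2ccccc2[nH]1` share one core and differ only in the ring carried on the benzyl ether. In a functional assay on HT-29 cells (Homo sapiens) for inhibition, read by MTT assay, with a stated time of 48 h (a higher number here means a weaker inhibitor, a lower number a stronger inhibitor), compound 1 gives 8200 nM, the lower of the two numbers, while compound 2 gives 23700 nM. That step, a 2.9-fold higher number from compound 1 to compound 2 (0.46 log units; beyond the scatter), was modest yet beyond the scatter. Compound 3 `Cc1ccc(NC(=S)NC(=O)c2ccc(OCc3ccc(Cl)c(Cl)c3)cc2)cc1-c1nc2ccccc2[nH]1` is not yet measured; it differs from compound 1 by 3,4-dichlorophenyl in place of 3-(trifluoromethyl)phenyl on a saturated chain carbon bound to an oxygen on an aromatic ring. For the measured compounds named here, only the step from compound 1 to compound 2 bears on this change, and it was modest, so a modest rise or no change beyond the scatter is expected, a 1.5-fold higher number from compound 1 to compound 3 (0.17 log units; within the scatter). Compound 3 is estimated at 12000 nM, within 5000 nM to 30000 nM.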

Compound 3, half-maximal inhibitory concentration: 6270 nM
Beside the measured number, compound 3's estimate is 1.9-fold (0.28 log units) above it; low and high end bracket the measured number.
By their numbers in this assay, from the lowest: compounds 3 and 1 (each within the scatter of the next); then compound 2.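

In this assay, 3,4-dichlorophenyl and 3-(trifluoromethyl)phenyl cannot be told apart at this position (a 1.3-fold lower number from compound 1 to compound 3 (0.12 log units; within the scatter)). Carrying chlorine does not by itself decide the outcome, since the two chlorinated rings do differ (a 3.8-fold lower number from compound 2 to compound 3 (0.58 log units; beyond the scatter)). Nothing measured here explains that difference. Still open, going by these compounds, is how this ring would behave with a methoxy group or an amine in place of the chlorine or trifluoromethyl groups. Also open, on these data alone, is whether a longer chain between the oxygen and the ring would keep these numbers.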